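A few compounds are considered here, and "the series" means these few. Any claim that something is new, unique, unknown or untested is made for them only; others in the source may bear on it.

Working notes on the amide series. For the measured compounds named here, the three measured members share one core and are compound 1 `CC(C)S(=O)(=O)n1c(N)nc2ccc(NC(=O)c3ccccc3Cl)cc21`, compound 2 `Cc1ccc(C(=O)Nc2ccc3nc(N)n(S(=O)(=O)C(C)C)c3c2)cc1` and compound 3 `CC(C)S(=O)(=O)n1c(N)nc2cc(NC(=O)c3ccccc3)ccc21`. In an ADME assay on HepG2 2.2.15 cells (Homo sapiens) for cytotoxicity, read by MTT assay, with a stated time of 6 h (a lower number here means that less compound is tolerated, a higher number that more compound is tolerated), compound 1 gives 88000 nM. Compound 2 stops at the limit of this assay, reported as > 500000 nM. Compound 3 likewise stops at the limit of this assay, reported as > 500000 nM. Going by the values given here, the only sized step between neighbours is an at least 5.6-fold higher number from compound 1 to compound 2 (0.75 log units; beyond the scatter), and it runs into the same limit; this is the limit of > 500000 nM in this assay, at which 2 of the 3 values shown sit, so compound 3 stands among the two members for which no number, only a limit, is known.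

Compound 4 `CC(C)S(=O)(=O)n1c(N)nc2cc(NC(=O)c3ccc(F)cc3)ccc21` differs from compound 3 by fluoro in place of hydrogen on an aromatic carbon. Among the compounds with values here, no measured step covers this exact change; the one sized step, an at least 5.6-fold higher number from compound 1 to compound 2 (0.75 log units; beyond the scatter), shows merely that another change on the phenyl of the amide left the value at the limit. Compound 4 is therefore expected to remain near the limit as well, which amounts to an expected step of a number no higher from compound 3 to compound 4 (the limit leaves the size open). The estimate for compound 4 in this assay is 500000 nM, with a range from 150000 nM to 1000000 nM.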

Compound 4, half-maximal cytotoxic concentration: 34000 nM
Estimate against measurement, compound 4: 15-fold (1.17 log units) above; the whole stated range lies above it.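

In this assay, the change from phenyl to 4-fluorophenyl gives an at least 14-fold lower number from compound 3 to compound 4 (1.16 log units; beyond the scatter), so a single fluoro, para to a large group, is enough to bring this amide off the limit. For the compounds shown here, the earlier compounds showed a change on the phenyl of the amide only as a step up to the limit; this is the first step down from it, and it shows that this place on the ring is not indifferent to substitution. The true size of the step stays open, as compound 3 carries a limit and not a number: the limit of > 500000 nM in this assay, at which 2 of the 4 values shown sit.

Going by these compounds, whether the drop belongs to fluoro alone remains open, as a methoxy group, an amine or a carboxylic acid at the same place could show. Equally open, on these data alone, is whether fluoro at another place on this phenyl would lower the number in the same way.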